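Sulfanyl in Place of Amino: An Untested Analogue

This account rests on a few compounds, and the source may have more. Where it says the series, first, only, none or still open, it means among the compounds named here.

Compound 1 `Nc1nc2cc(Cl)c(Cl)cc2n1COCCO` gives > 100000 nM in a functional assay on KB cells (Homo sapiens) for inhibition; on this read-out lower numbers stand for stronger inhibition and higher numbers for weaker inhibition; this value is a limit of the assay, not a number.
Compound 2 `OCCOCn1cnc2c(Cl)cc(Cl)cc21` gives > 100000 nM in this assay; this value too is a limit.

Compound 1 stands at the limit of > 100000 nM in this assay, at which 2 of the 2 values shown sit. Within the data shown here, every value shown is a limit, so the measured set offers no graded numbers and no step between measured compounds that could be traced.

Compound 3 `OCCOCn1c(S)nc2cc(Cl)c(Cl)cc21` differs from compound 1 by sulfanyl in place of amino on an aromatic carbon. Among the measured compounds shown here, no measured pair shows what such a change does. In this assay the expected step is none beyond the scatter, and most likely a further limit, because compound 1 already sits at the limit of > 100000 nM in this assay, at which 2 of the 2 values shown sit. Compound 3 is therefore expected to give about 100000 nM, with a range from 30000 nM to 300000 nM. This expectation corresponds to an estimated a number no higher from compound 1 to compound 3 (the limit leaves the size open), a step that is not expected to reach beyond the scatter.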

Compound 3, half-maximal inhibitory concentration: > 100000 nM
Compound 3: no number, only a limit; the forecaster's own chance of this, stated with the estimate: 80%; the middle value sits exactly at the limit.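

In this assay compound 3 gives > 100000 nM as a limit of the assay, not a number. Among these compounds, compound 1 also sits at a limit, so no step between compound 1 and compound 3 can be read, and the same holds across the set: the limit of > 100000 nM in this assay, at which 3 of the 3 values shown sit. On these data alone, whether sulfanyl in place of amino changes inhibition at all stays open.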